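Amine methylation in a cage-amine series at the alpha-2C receptor

The source may report more compounds than this note shows. Statements on the series, on what has been measured and on what is new or still open speak of the compounds shown alone.

The series is built on one shared saturated cage core carrying an amine that links to a benzylic or longer arm. Compound 1 `Fc1cccc(CCCN[C@H]2C3C4CC5C6C4CC3C6C52)c1` carries a three-carbon chain to a fluorinated phenyl ring; in an assay on isolated protein for inhibition of Alpha-2C adrenergic receptor (Homo sapiens) (a higher number here means a weaker inhibitor, a lower number a stronger inhibitor), compound 1 has only the entry "not determined" (no result reported). Compound 2 `COc1cc(CN[C@H]2C3C4CC5C6C4CC3C6C52)cc(OC)c1OC` carries a trimethoxybenzyl arm and gives 2280 nM, the lowest of the two numbers available. Compound 3 `CN(Cc1cccc(F)c1)[C@H]1C2C3CC4C2C(=O)C2C4C3C21` differs in several places at once, with a ketone in the core and a fluorinated benzyl arm, and gives 5050 nM; its number stands higher than that of compound 2 by a margin beyond the scatter, but with more than one change between the two, no single cause can be read from the pair.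

Compound 4 `COc1cc(CN(C)[C@H]2C3C4CC5C6C4CC3C6C52)cc(OC)c1OC` is the one-place variant of compound 2: methyl in place of hydrogen on an amine nitrogen. Going by the values given here, no measured pair in the set isolates this change. With only the trend of compound 3 as loose context, a step upward within the scatter is the working expectation, so the estimated step is a 1.5-fold higher number from compound 2 to compound 4 (0.19 log units; within the scatter). For compound 4 the expected value in this assay is 3500 nM, with a range from 1200 nM to 10000 nM.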

Compound 4, inhibition constant: 2520 nM
The estimate for compound 4 lay 1.4-fold (0.14 log units) above the measured number; the range from low to high includes it.
By their numbers in this assay, from the lowest: compounds 2, 4 and 3 (each within the scatter of the next, the first and the last beyond it).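

In this assay, methyl in place of hydrogen on an amine nitrogen gives a 1.1-fold higher number from compound 2 to compound 4 (0.04 log units; within the scatter), with the trimethoxybenzyl arm and the shared core held fixed. Going by these compounds alone, this is the first reading of the change on its own, which the several differences between compound 2 and compound 3 could not provide, and it shows that in this one pair the hydrogen on this nitrogen can be replaced by methyl without a step beyond the scatter. No supporting data bear on why the two compounds read so closely, so the result stands as an observation only.

On these data alone, it remains open whether the same replacement gives a comparable step with other arms, such as the fluorinated benzyl arm of compound 3 or the longer chain of compound 1, or with the ketone in the core of compound 3. As far as these compounds go, it is also open how this nitrogen responds to something other than methyl, such as an ethyl group, a 2-hydroxyethyl group or an acetyl group that would turn the amine into an amide.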